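Sulfonamide-amine series: trifluoromethyl benzyl replaces dimethoxy benzyl

The source may report more compounds than this note shows. Statements on the series, on what has been measured and on what is new or still open speak of the compounds shown alone.

Measured so far, in a functional assay on PANC-1 cells (Homo sapiens) for inhibition, read by MTT assay, with a stated time of 72 h; a higher number here means a weaker inhibitor of growth, a lower number a stronger inhibitor of growth:
compound 1 `CC(C)(C)c1ccc(CNCCNS(=O)(=O)c2cc(C(F)(F)F)cc(C(F)(F)F)c2)cc1` gives 13000 nM
compound 2 `O=S(=O)(NCCCCNCc1ccc(Br)cc1)c1cc(C(F)(F)F)cc(C(F)(F)F)c1` gives 2200 nM
compound 3 `COc1ccc(CNCCCNS(=O)(=O)c2cc(C(F)(F)F)cc(C(F)(F)F)c2)cc1OC` gives 18000 nM

Compound 3 carries the highest number of the three. For the measured compounds named here, its gap to compound 1 lies within the scatter, so the two cannot be ordered against each other; its gap to compound 2 lies beyond the scatter, and compound 2 is the one member of the set that stands clearly apart on the lower side. Going by the values given here, no pair of measured compounds differs in a single place, so no step between them can be separated from the rest of the structural variation.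

Compound 4 `O=S(=O)(NCCCNCc1ccc(C(F)(F)F)cc1)c1cc(C(F)(F)F)cc(C(F)(F)F)c1` is the next member to be measured in this assay. It differs from compound 3 as follows: 4-(trifluoromethyl)phenyl in place of 3,4-dimethoxyphenyl on a saturated chain carbon bound to an amine nitrogen. The shared core and the chain length are unchanged.

Only compound 2, which also carries a single substituent on its benzyl ring, offers a hint that a lower number is possible here. An improvement is expected from compound 3 to compound 4, of moderate size, a 3.0-fold lower number from compound 3 to compound 4 (0.48 log units; beyond the scatter), though a result within the scatter would not be surprising. Compound 4 is estimated at 6000 nM, with a range from 2000 nM to 18000 nM.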

Compound 4, concentration for 50% growth inhibition: 3200 nM
The estimate for compound 4 lay 1.9-fold (0.27 log units) above the measured number; measured number inside the range.
By their numbers in this assay, from the lowest: compounds 2 and 4 (each within the scatter of the next); then compounds 1 and 3 (each within the scatter of the next).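

In this assay, for the compounds shown here, 4-(trifluoromethyl)phenyl in place of 3,4-dimethoxyphenyl gives a 5.6-fold lower number from compound 3 to compound 4 (0.75 log units; beyond the scatter), the first step that can be read at a single place, on a saturated chain carbon bound to an amine nitrogen. This place therefore responds to the choice of substituents on the aromatic ring, even though the heavy-atom count is the same on both sides and the hydrogen-bond acceptors of the leaving group are absent from the entering one. No measurement bears on what lies behind the step.

On these data alone, the change alters the kind and number of ring substituents together, so it remains open whether 4-methoxyphenyl or unsubstituted phenyl would stand nearer compound 3 or compound 4. As far as these compounds go, whether the same replacement holds on the differing chains of compound 1 and compound 2 is also open.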